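Replacing the Hydroxy on the Sulfonyl Sulfur of Compound 2

The compounds below may be only part of what the source reports. "The series", "measured", "known", "first", "only" and "open" are said of these compounds alone.

Of the compounds shown here, two have been measured in an assay on HEK293 cells for inhibition of solute carrier family 22 member 12 (Homo sapiens); a higher number here means a weaker inhibitor, a lower number a stronger inhibitor. Compound 1 `O=C(CSc1nnc(Br)n1Cc1ccc(Br)c2ccccc12)NO` gives 640 nM. Compound 2 `O=S(=O)(O)CSc1nnc(Br)n1Cc1ccc(Br)c2ccccc12` gives 14400 nM, the highest of the two numbers. Among the compounds with values here, the one measured step, a 23-fold higher number from compound 1 to compound 2 (1.35 log units; beyond the scatter), is a large one and shows sulfo in place of hydroxycarbamoyl on a saturated chain carbon bound to a sulfur.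

Compound 3 `O=S(=O)(CSc1nnc(Br)n1Cc1ccc(Br)c2ccccc12)Nc1cc(Cl)cnc1Cl` has not yet been measured. It differs from compound 2 in one place: (2,5-dichloropyridin-3-yl)amino in place of hydroxy on a sulfonyl sulfur.

Within the data shown here, no measured step bears directly on this change; the single step in hand, a 23-fold higher number from compound 1 to compound 2 (1.35 log units; beyond the scatter), concerns the exchange at the saturated chain carbon and not the group on the sulfonyl sulfur. That step does show that compound 2 with its sulfo group stands well above compound 1 in this assay, so exchanging the hydroxy on the sulfonyl sulfur for (2,5-dichloropyridin-3-yl)amino could move the number back down, though how far is uncertain. Compound 3 is therefore expected to give 2000 nM, within a range of 300 nM to 12000 nM, which means an estimated step of a 7.2-fold lower number from compound 2 to compound 3 (0.86 log units; beyond the scatter).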

Compound 3, half-maximal inhibitory concentration: 2790 nM
For compound 3 the middle estimate is 1.4-fold (0.14 log units) below the measured one, and the stated range covers the measured number.
By their numbers in this assay, from the lowest: compound 1; then compound 3; then compound 2.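

In this assay the sulfonyl sulfur proves to be a place where exchanging the group changes the number: a 5.2-fold lower number from compound 2 to compound 3 (0.71 log units; beyond the scatter), a modest step, comes with (2,5-dichloropyridin-3-yl)amino in place of hydroxy. The exchange replaces 1 heavy atom with 9 heavy atoms and adds a six-membered aromatic ring with 1 hetero atom, so this place on a sulfonyl sulfur, whose other neighbour is a saturated chain carbon, accepts a larger group without the number rising. Nothing at hand accounts for the step or separates the part played by the ring from that played by the amino link.

What the compounds shown leave open is whether the two chlorines take part in the step, a question that an unsubstituted pyridin-3-ylamino or a phenylamino group at this place would address. Equally open, going by these compounds, is how a small group, such as plain amino or methylamino on the sulfonyl sulfur, would compare with both hydroxy and (2,5-dichloropyridin-3-yl)amino.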